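A few compounds are considered here, and "the series" means these few. Any claim that something is new, unique, unknown or untested is made for them only; others in the source may bear on it.

Measured in a functional assay on DU-145 cells (Homo sapiens) for cytotoxicity, read by MTT assay, with a stated time of 48 h; on this read-out higher numbers stand for weaker inhibition and lower numbers for stronger inhibition:
- compound 1 `COc1ccc(/C=C/c2cc(OC)c(OC)c(OC)c2-c2ccccc2)cc1`: 51000 nM
- compound 2 `COc1cc(/C=C/c2ccc(C)cc2)c(-c2ccccc2)c(OC)c1OC`: 101000 nM

Only these two values are available, and they lie within the scatter of each other. Among the measured compounds shown here, compound 2, at 101000 nM, therefore cannot be separated from its sole neighbour, compound 1.

The next compound is compound 3 `C=C(c1ccc(C)cc1)c1cc(OC)c(OC)c(OC)c1-c1ccccc1`, with the same atoms as compound 2 joined differently: 1-(4-methylphenyl)ethenyl in place of 2-(4-methylphenyl)ethenyl on an aromatic carbon. 1-(4-methylphenyl)ethenyl stands in place of 2-(4-methylphenyl)ethenyl on an aromatic carbon, ortho to a phenyl group and para to a methoxy group.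

For the measured compounds named here, the only measured step, a 2.0-fold higher number from compound 1 to compound 2 (0.30 log units; within the scatter), is methyl in place of methoxy on an aromatic carbon. It is a different change and stays within the scatter. Going by the values given here, no measured pair tests the present change, so the expectation in this assay is weakly founded, and no direction can be argued from the data. A step beyond the scatter is not expected.

The expected step is a 1.3-fold lower number from compound 2 to compound 3 (0.10 log units; within the scatter).

For compound 3 the estimate is 80000 nM, with an expected range of 25000 nM to 200000 nM.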

Compound 3, half-maximal inhibitory concentration: 28000 nM
The estimate for compound 3 lay 2.9-fold (0.46 log units) above the measured number; the range from low to high includes it.
By their numbers in this assay, from the lowest: compounds 3, 1 and 2 (each within the scatter of the next, the first and the last beyond it).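

In this assay, among the compounds shown here, 1-(4-methylphenyl)ethenyl in place of 2-(4-methylphenyl)ethenyl gives a 3.6-fold lower number from compound 2 to compound 3 (0.56 log units; beyond the scatter) and is the first step to lie beyond the scatter, though only modestly, whereas the earlier methyl-for-methoxy change, a 2.0-fold higher number from compound 1 to compound 2 (0.30 log units; within the scatter), did not. The two groups have the same atoms and the same counts of rings and double bonds, so this aromatic carbon, ortho to a phenyl group and para to a methoxy group, responds to how the group is joined even with its composition unchanged. Nothing at hand accounts for this difference.

From the compounds shown here alone, it remains open whether the lower number of compound 3 depends on the methyl group of 1-(4-methylphenyl)ethenyl, since the methyl-for-methoxy change has been read only on the 2-(4-methylphenyl)ethenyl group. Also open, going by these compounds, is how the 1-substituted ethenyl group behaves when that methyl is replaced by an amine or a hydroxyl group, or when the phenyl group on the neighbouring ring carbon of the core is replaced by a longer alkyl chain.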